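The compounds below may be only part of what the source reports. "The series", "measured", "known", "first", "only" and "open" are said of these compounds alone.

Measured in a functional assay on HepG2 cells (Homo sapiens) for inhibition, read by MTT assay, with a stated time of 72 h; on this read-out higher numbers stand for weaker inhibition and lower numbers for stronger inhibition:

Compound 1 `N#Cc1ccccc1-n1cc(COc2cccc(NC(=O)Nc3ccc(Cl)c(C(F)(F)F)c3)c2)nn1` gives 1970 nM.
Compound 2 `CCc1ccccc1-n1cc(COc2cccc(NC(=O)Nc3ccc(Cl)c(C(F)(F)F)c3)c2)nn1` gives 3530 nM.
Compound 3 `CC(C)c1ccc(-n2cc(COc3cccc(NC(=O)Nc4ccc(Cl)c(C(F)(F)F)c4)c3)nn2)cc1` gives 2470 nM.

On these three numbers compound 3 stands second highest, with compound 1 its nearest neighbour and compound 2 its furthest, both inside the scatter.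

Compound 4 `O=C(Nc1cccc(OCc2cn(-c3ccc(Br)cc3)nn2)c1)Nc1ccc(Cl)c(C(F)(F)F)c1` differs from compound 3 in one place:

bromo in place of isopropyl on an aromatic carbon

The two steps already measured that change the group on the same ring bear on this: a 1.3-fold higher number from compound 1 to compound 3 (0.10 log units; within the scatter) and a 1.4-fold lower number from compound 2 to compound 3 (0.16 log units; within the scatter), both within the scatter. Swapping groups at this place has so far left the number where it was, so for compound 4 no step beyond the scatter is expected in this assay: a 1.0-fold higher number from compound 3 to compound 4 (0.01 log units; within the scatter). Compound 4 is therefore estimated at 2500 nM, in a range from 1200 nM to 5500 nM.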

Compound 4, half-maximal inhibitory concentration: 2730 nM
The estimate for compound 4 lay 1.1-fold (0.04 log units) below the measured number; the range from low to high includes it.
By their numbers in this assay, from the lowest: compounds 1, 3, 4 and 2 (each within the scatter of the next).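

In this assay, a single bromine atom takes the place of the isopropyl group's 3 carbons on the phenyl ring with only a 1.1-fold higher number from compound 3 to compound 4 (0.04 log units; within the scatter), so a much smaller group with no carbon leaves the number in place. The 4-bromophenyl group also stays level with both groups on the nitrogen that carry a substituent at another ring position: a 1.3-fold lower number from compound 2 to compound 4 (0.11 log units; within the scatter) and a 1.4-fold higher number from compound 1 to compound 4 (0.14 log units; within the scatter). No measurement here offers a reason for this flat picture.

Still open, going by these compounds, is whether an amine, a carboxylic acid or a longer chain on this ring would move the number beyond the scatter. The compounds shown also say nothing about changes elsewhere in the shared core.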